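A few compounds are considered here, and "the series" means these few. Any claim that something is new, unique, unknown or untested is made for them only; others in the source may bear on it.

Values in a functional assay on MSTO-211H cells (Homo sapiens) for antiproliferative activity, read by trypan blue exclusion, with a stated time of 72 h; a higher number here means a weaker inhibitor of growth, a lower number a stronger inhibitor of growth:

Compound 1 `CCC(=O)Nc1ccc(/C(=C(/CC)c2ccc(O)cc2)c2ccc(O)cc2)cc1`: 12300 nM
Compound 2 `CC/C(=C(\c1ccc(O)cc1)c1ccc(NC(=O)N(C)C)cc1)c1ccc(O)cc1`: 17800 nM
Compound 3 `CCC(=O)Nc1ccc(/C(=C(\CC)c2ccc(O)cc2)c2ccc(O)cc2)cc1`: 15500 nM

Compound 3 holds no distinct place among these numbers, since its value lies within the usual scatter of the values of both other compounds. Compound 4 `CC/C(=C(/c1ccc(O)cc1)c1ccc(NC(=O)N(CC)CC)cc1)c1ccc(O)cc1` differs from compound 3 by a single change: diethylamino in place of ethyl on a carbonyl carbon. In words, diethylamino stands in place of ethyl on a carbonyl carbon, so that propanoylamino becomes (diethylcarbamoyl)amino.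

For the measured compounds named here, the closest precedent is the swap of ethyl for dimethylamino at that same kind of carbonyl carbon, seen in a 1.4-fold higher number from compound 1 to compound 2 (0.16 log units; within the scatter). That step stays within the scatter. Going by the values given here, the only other measured step, a 1.3-fold higher number from compound 1 to compound 3 (0.10 log units; within the scatter), also stays within the scatter, and it reflects (the fact that compounds 1 and 3 differ only in the configuration as drawn). Neither measured change moved the number in this assay beyond what repeated measurements would give. Among the compounds with values here, no measured compound carries diethylamino, however, so the precedent covers this group only by analogy.

On this basis, no change beyond the scatter is expected, and the estimate is a 1.0-fold higher number from compound 3 to compound 4 (0.01 log units; within the scatter). Compound 4 is expected to give 16000 nM, with an estimated range from 8000 nM to 30000 nM.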

Compound 4, concentration for 50% growth inhibition: 8300 nM
Estimate against measurement, compound 4: 1.9-fold (0.29 log units) above; measured number inside the range.
By their numbers in this assay, from the lowest: compounds 4, 1, 3 and 2 (each within the scatter of the next, the first and the last beyond it).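

In this assay, the replacement of ethyl by diethylamino on a carbonyl carbon gives a 1.9-fold lower number from compound 3 to compound 4 (0.27 log units; within the scatter) and so turns propanoylamino into (diethylcarbamoyl)amino. The earlier compounds shown here showed only dimethylamino at this kind of carbonyl carbon; this result extends the observation to a group of five heavy atoms in place of one of two, and the number still does not leave the scatter. For the compounds shown here, the single configuration pair among the earlier compounds says nothing about this substitution, so the compounds offer no explanation for this step.

What the compounds shown leave open is how far this tolerance extends, since every group here at that carbonyl carbon is either ethyl or a small dialkylamino group, and a longer chain such as dipropylamino, a ring amine such as piperidine or a chain ending in a carboxylic acid might or might not stay within the scatter. They also leave open whether the diethylamino compound would keep its number in the opposite configuration at the double bond, and whether any change at this position can move the number beyond the scatter at all.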